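This account rests on a few compounds, and the source may have more. Where it says the series, first, only, none or still open, it means among the compounds named here.

Measured compounds:
compound 1, `FC(F)c1ccccc1`, 2.4 in a physicochemical assay for lipophilicity, read by spectrophotometry, using the shake flask method, measured as octanol-water partition; a lower number here means a more polar compound, a higher number a more lipophilic compound
compound 2, `FC(F)SCCc1ccccc1`, 3.16 in this assay
compound 3, `O=S(=O)(CCc1ccccc1)C(F)F`, 1.87 in this assay

Among these three numbers compound 2 gives the highest value in this assay; compound 1 is the nearest, its number lower by a margin beyond the scatter, and compound 3 lies furthest, lower again beyond the scatter. No pair of these compounds differs in only one place, so no single step among them is known.

Compound 4, `FC(F)CCc1ccccc1`, has not yet been measured. It differs from compound 2 by difluoromethyl in place of (difluoromethyl)sulfanyl on a saturated chain carbon, two bonds along the chain from an aromatic carbon. Within the data shown here, with no comparable step available, the expected change in this assay is a moderate fall beyond the scatter, the step from compound 2 to compound 4 estimated at a number 0.46 log units lower from compound 2 to compound 4 (beyond the scatter). Compound 4 is thus expected at 2.7, within 2.3 to 3.1.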

Compound 4, partition coefficient: 3.02
Beside the measured number, compound 4's estimate is 0.32 log units below it, and the stated range covers the measured number.
By their numbers in this assay, from the lowest: compound 3; then compound 1; then compounds 4 and 2 (each within the scatter of the next).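

On a saturated chain carbon, two bonds along the chain from an aromatic carbon, difluoromethyl in place of (difluoromethyl)sulfanyl gives a number 0.14 log units lower from compound 2 to compound 4 (within the scatter) in this assay. Among these compounds, this is the first single change read, and at this position the exchange, which removes the sulfur atom, stays within the scatter. Nothing measured here bears on why the two compounds stand so close. Going by these compounds, whether the same exchange holds on a longer chain, or in a core carrying an amine or a carboxylic acid, stays open.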